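Pyrrolidin-1-yl to Ethylamino: Expectation for Compound 4

This account rests on a few compounds, and the source may have more. Where it says the series, first, only, none or still open, it means among the compounds named here.

Measured so far:
compound 1, `Cc1nnc(CN(C)C)n1-c1ccc(Cl)cc1C(=O)c1ccccc1`: 1.1 mg/kg
compound 2, `Cc1nnc(CN2CCCC2)n1-c1ccc(Cl)cc1C(O)c1ccccc1`: 14 mg/kg
compound 3, `Cc1nnc(CN2CCCC2)n1-c1ccc(Cl)cc1C(=O)c1ccccc1`: 2 mg/kg

In a functional assay on the whole organism (strain CF-1) for inhibition, with Mus musculus as the target (on this read-out higher numbers stand for an effect only at larger amounts of compound and lower numbers for an effect already at smaller amounts), compound 3 gives 2 mg/kg, the second highest of the three numbers. The nearest is compound 1, seen in a 1.8-fold higher number from compound 1 to compound 3 (0.26 log units; within the scatter), which is within the scatter; the furthest is compound 2, seen in a 7.0-fold lower number from compound 2 to compound 3 (0.85 log units; beyond the scatter), which lies beyond it.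

Compound 4, `CCNCc1nnc(C)n1-c1ccc(Cl)cc1C(=O)c1ccccc1`, differs from compound 3 by ethylamino in place of pyrrolidin-1-yl on a saturated chain carbon bound to an aromatic carbon. Within the data shown here, the only measured step at that place is a 1.8-fold higher number from compound 1 to compound 3 (0.26 log units; within the scatter), which stayed within the scatter, though it exchanged one group without a hydrogen-bond donor for another. Among the measured compounds shown here, no measured step introduces ethylamino. Compound 4 is therefore expected to show a step of a 1.3-fold higher number from compound 3 to compound 4 (0.10 log units; within the scatter), not beyond the scatter, giving an estimated 2.5 mg/kg in this assay, with a range from 1 mg/kg to 6 mg/kg.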

Compound 4, dose for half-maximal effect: 0.5 mg/kg
Compound 4: middle estimate off by 5.0-fold (0.70 log units), on the high side; measured number below the stated range.
By their numbers in this assay, from the lowest: compound 4; then compounds 1 and 3 (each within the scatter of the next); then compound 2.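

Ethylamino is the first group at this place to move the number beyond the scatter in this assay: it gives a 4.0-fold lower number from compound 3 to compound 4 (0.60 log units; beyond the scatter) and also a 2.2-fold lower number from compound 1 to compound 4 (0.34 log units; beyond the scatter). Unlike pyrrolidin-1-yl, it carries a hydrogen-bond donor and has no ring, and the compounds shown do not separate these two differences. Nothing available accounts for the lower number. Going by these compounds, it remains open whether methylamino or an unsubstituted amine at this place would match ethylamino. On these data alone, it is also open whether ethylamino would give a similar step alongside hydroxy(phenyl)methyl in place of benzoyl.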